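Cytotoxicity in a thiadiazole amide series, dichlorophenyl to phenyl

The source may report more compounds than this note shows. Statements on the series, on what has been measured and on what is new or still open speak of the compounds shown alone.

Compound 2 `CC(CSc1nnc(-c2ccncc2)s1)C(=O)Nc1ccc(Cl)cc1Cl` is the reference point. In an ADME assay on HepG2 cells (Homo sapiens) for cytotoxicity, with a stated time of 3 days (a lower number here means that less compound is tolerated, a higher number that more compound is tolerated), compound 2 gives > 50000 nM, which is a limit of the assay and not a number. Compound 3 `O=C(CCSc1nnc(-c2ccncc2)s1)Nc1ccc(Cl)cc1Cl`, with hydrogen in place of methyl on a saturated chain carbon bound to a carbonyl carbon and a saturated chain carbon, gives > 50000 nM in this assay, again only a limit. The step that the two limits leave unreadable from compound 2 to compound 3 therefore cannot be read. Compound 1 `CC(Sc1nnc(-c2ccncc2)s1)C(=O)NCc1ccccc1Cl` gives > 50000 nM in this assay, also a limit. Among the measured compounds shown here, every value so far sits at the limit of > 50000 nM in this assay, at which 3 of the 3 values shown sit.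

Compound 4 `CC(CSc1nnc(-c2ccncc2)s1)C(=O)Nc1ccccc1` differs from compound 2 as follows: phenyl in place of 2,4-dichlorophenyl on an amide-type nitrogen. For the measured compounds named here, no measured step exchanges the group on the amide-type nitrogen, so none bears directly on this change, and the single measured step that the two limits leave unreadable from compound 2 to compound 3 is unreadable. Compound 4 is expected to move by a step that the limit leaves unreadable from compound 2 to compound 4, no step beyond the scatter. The estimate for compound 4 in this assay is 70000 nM, within 25000 nM to 200000 nM, because the limit of > 50000 nM in this assay, at which 3 of the 3 values shown sit, describes the whole series measured so far.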

Compound 4, half-maximal cytotoxic concentration: > 50000 nM
Compound 4: only a limit was reported (the forecaster's own chance of this, stated with the estimate: 70%); the middle value is on the limit's open side.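

In this assay compound 4 gives > 50000 nM, which is a limit and not a number, so its step from compound 2 cannot be read. The compounds shown leave open the concentration at which any of them becomes cytotoxic, and whether phenyl in place of 2,4-dichlorophenyl changes it.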